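Adding propylsulfanyl to compound 3

A few compounds are considered here, and "the series" means these few. Any claim that something is new, unique, unknown or untested is made for them only; others in the source may bear on it.

- compound 1 `CCCSC(=O)COC(=O)C1=C2C(=NC1=O)c1cccc3cccc2c13`: 10500 nM
- compound 2 `CCCSc1ccc2c3c(cccc13)C1=NC(=O)C(C(=O)OCC)=C12`: 1700 nM
- compound 3 `O=C(COC(=O)C1=C2C(=NC1=O)c1cccc3cccc2c13)OCC(F)(F)C(F)(F)F`: 19000 nM

In a functional assay on T-24 cells (Homo sapiens) for antiproliferative activity, read by sulforhodamine B assay, with a stated time of 72 h (on this read-out lower numbers stand for stronger inhibition and higher numbers for weaker inhibition), compound 3 shares the upper end of these numbers with compound 1, as the step is only a 1.8-fold higher number from compound 1 to compound 3 (0.26 log units; within the scatter). Compound 2 lies lower than compound 3, beyond the scatter.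

Compound 4 `CCCSc1ccc2c3c(cccc13)C1=NC(=O)C(C(=O)OCC(=O)OCC(F)(F)C(F)(F)F)=C12` keeps the side chain of compound 3 and adds (propylsulfanyl in place of hydrogen on an aromatic carbon). Among the measured compounds shown here, the one measured step concerns the end of that chain, so no measured step isolates this change. Only compound 2, at 1700 nM, carries propylsulfanyl on an aromatic carbon, but its side chain differs as well. A move to a lower number, beyond the scatter, is therefore expected. The expected change is a 4.2-fold lower number from compound 3 to compound 4 (0.63 log units; beyond the scatter). For compound 4 the estimated value is 4500 nM, with an expected range of 1200 nM to 17000 nM.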

Compound 4, half-maximal inhibitory concentration: > 100000 nM
Compound 4 ended at the assay's limit; the forecaster's own chance of this, stated with the estimate: 7%; middle value at least 22-fold (1.34 log units) from the limit.
By their numbers in this assay, from the lowest: compound 2; then compounds 1 and 3 (each within the scatter of the next). At a limit, above all of these: compound 4.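

Compound 4 gives a limit rather than a number in this assay: the limit of > 100000 nM in this assay, at which 1 of the 4 values shown sits. On the side chain of compound 3, propylsulfanyl in place of hydrogen on an aromatic carbon gives an at least 5.2-fold higher number from compound 3 to compound 4 (0.72 log units; beyond the scatter), so the lower number of compound 2 does not carry over to this side chain. With propylsulfanyl kept, (2,2,3,3,3-pentafluoropropoxy)carbonyl in place of methyl on the saturated chain carbon gives an at least 58-fold higher number from compound 2 to compound 4 (1.76 log units; beyond the scatter). The compounds shown leave open whether methylsulfanyl or an amine on this aromatic carbon would behave the same way on that side chain. They also leave open how a carboxylic acid at the chain end would read alongside propylsulfanyl.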